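The source may report more compounds than this note shows. Statements on the series, on what has been measured and on what is new or still open speak of the compounds shown alone.

Measured so far:
compound 1, `COc1cc2ncnc(NNC(=S)NC(=O)c3ccc(F)cc3)c2cc1OC`: 8300 nM
compound 2, `O=C(NC(=S)NNc1ncnc2ccccc12)c1ccccc1`: 6990 nM

Both numbers come from a functional assay on MGC-803 cells (Homo sapiens) for cytotoxicity, read by MTT assay, with a stated time of 72 h; on this read-out higher numbers stand for weaker inhibition and lower numbers for stronger inhibition. Compound 1 carries the higher of the two, and compound 2, with the lower number, lies within the scatter of it, so the two cannot be ordered against each other. Within the data shown here, no pair of measured compounds differs in a single place, so no step size has been measured.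

Compound 3, `COc1cc2ncnc(NNC(=S)NC(=O)c3ccccc3F)c2cc1OC`, has not yet been measured. It differs from compound 1 in one place: 2-fluorophenyl in place of 4-fluorophenyl on a carbonyl carbon. The same atoms are kept and joined differently; on the carbonyl carbon 4-fluorophenyl gives way to 2-fluorophenyl. Among the measured compounds shown here, no measured step informs this kind of change. The step of a 1.0-fold lower number from compound 1 to compound 3 (0.02 log units; within the scatter) is expected to stay within the scatter, with no clear direction. Compound 3 is estimated at 8000 nM, within 3000 nM to 22000 nM.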

Compound 3, half-maximal inhibitory concentration: 2390 nM
Compound 3: middle estimate off by 3.3-fold (0.52 log units), on the high side; measured number outside the range, below it.
By their numbers in this assay, from the lowest: compound 3; then compounds 2 and 1 (each within the scatter of the next).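

In this assay, 2-fluorophenyl in place of 4-fluorophenyl on the carbonyl carbon gives a 3.5-fold lower number from compound 1 to compound 3 (0.54 log units; beyond the scatter), the first single change measured in the series. This position therefore responds to where the fluorine sits on the phenyl ring, even though the two groups have the same atoms; compounds 1 and 2 could not show this, as they differ in more than one place. No measured data accompany this step to explain it.

Still open, going by these compounds, is whether the step depends on fluorine itself or would also appear with 2-chlorophenyl or 2-methylphenyl on the same carbonyl carbon. Also open, on these data alone, is whether the same change would give a similar step on the core of compound 2, which lacks the two methoxy groups.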